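Nitro for dimethylamino on the aryl ring of compound 2

A few compounds are considered here, and "the series" means these few. Any claim that something is new, unique, unknown or untested is made for them only; others in the source may bear on it.

Two compounds in the series carry numbers in an assay for binding affinity to adenosine receptor A1 (Bos taurus); a lower number here means a stronger inhibitor, a higher number a weaker inhibitor. Compound 1 `CCn1c(=O)c2nc(-c3ccc(S(=O)(=O)N4CCOCC4)cc3)[nH]c2n(CC)c1=O` gives 13 nM there. Compound 2 `CN(C)c1cccc(-c2nc3c(=O)n(C)c(=O)n(C)c3[nH]2)c1` gives 80 nM in this assay, the higher of the two numbers, set apart from compound 1 by a gap beyond the scatter. Compound 3 `Cn1c(=O)c2nc(-c3cccc([N+](=O)[O-])c3)[nH]c2n(C)c1=O` has not yet been measured. It differs from compound 2 in one place: nitro in place of dimethylamino on an aromatic carbon. Among the compounds with values here, no step between measured compounds of this kind is at hand, so the expectation rests on compound 2 alone, and a step from compound 2 to compound 3 of a 1.6-fold lower number from compound 2 to compound 3 (0.20 log units; within the scatter) is estimated, not clearly beyond the scatter in either direction. Compound 3 is expected to give about 50 nM in this assay, within 15 nM to 200 nM.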

Compound 3, half-maximal inhibitory concentration: 50 nM
For compound 3 middle estimate and measured number coincide at the digits printed, and the stated range covers the measured number.
By their numbers in this assay, from the lowest: compound 1; then compounds 3 and 2 (each within the scatter of the next).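

On an aromatic carbon meta to a large group, nitro in place of dimethylamino gives a 1.6-fold lower number from compound 2 to compound 3 (0.20 log units; within the scatter) in this assay. The two groups share a heavy-atom count but differ in their atoms and hydrogen-bond acceptors, and this assay does not separate them at this position. Nothing available bears on the reason for this result. Open, going by these compounds, is how a carboxylic acid, a primary amine or a longer alkyl chain would read at this carbon. Also open, on these data alone, is whether nitro and dimethylamino would stay within the scatter of each other on the core of compound 1.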